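Indanyl to tolyl exchange on the ring amide nitrogen

A few compounds are considered here, and "the series" means these few. Any claim that something is new, unique, unknown or untested is made for them only; others in the source may bear on it.

Compound 1 `C/C(NNC(=S)N1CCc2cc(C(=O)O)ccc21)=C1/C(=O)N(c2ccc3c(c2)CCC3)c2ccccc21` gives 75.8% in an assay on BaF3 cells for inhibition of thrombopoietin receptor (Homo sapiens), tested at 300 nM (on this read-out lower numbers stand for a weaker effect and higher numbers for a stronger effect at the one concentration tested), and stands highest of the two numbers; compound 2 `C/C(NNC(=S)N1CCc2cc(C(=O)O)ccc21)=C1/C(=O)N(c2ccc3c(c2)CCC3)c2ccc(F)cc21` gives 10.6%, with a number 65.2 percentage points lower from compound 1 to compound 2 (beyond the scatter). Compound 3 `C/C(NNC(=S)N1CCc2cc(C(=O)O)ccc21)=C1/C(=O)N(c2ccc(C)cc2)c2ccccc21` carries 4-methylphenyl in place of 2,3-dihydro-1H-inden-5-yl on an amide-type nitrogen in a ring. Within the data shown here, no measured step touches the group on the amide-type nitrogen, so the fluoro step offers no guide here; the series only shows that the read-out can swing widely. Compound 3 is therefore expected to lose some effect, estimated at 50% (range 15% to 80%), a step of a number 25.8 percentage points lower from compound 1 to compound 3 (beyond the scatter).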

Compound 3, a percentage reported as inhibition, at one concentration (the size of the read-out at that concentration, not a potency): 107%
For compound 3 the middle estimate is 57 percentage points below the measured one, and the stated range ends below it.
By their numbers in this assay, from the lowest: compound 2; then compound 1; then compound 3.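

On the amide-type nitrogen in a ring, the read-out in this assay responds strongly to the aryl group: 4-methylphenyl in place of 2,3-dihydro-1H-inden-5-yl gives a number 31.2 percentage points higher from compound 1 to compound 3 (beyond the scatter). The five-membered non-aromatic ring of carbon only is therefore not required for a high number in this series. No available measurement explains the step.

Still open, from the compounds shown here alone, is how a methoxy group or an unsubstituted phenyl would read in place of 4-methylphenyl. Also open, going by these compounds, is whether fluoro in place of hydrogen on an aromatic carbon would lower the number for compound 3 as it does for compound 1.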